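The source may report more compounds than this note shows. Statements on the series, on what has been measured and on what is new or still open speak of the compounds shown alone.

Measured so far:
- compound 1 `COc1nc(NC2CC2)c2ncn([C@H]3C[C@H](N=[N+]=[N-])[C@@H](CO)O3)c2n1`: > 100000 nM
- compound 2 `CC(C)(CO)Nc1nc(N)nc2c1ncn2[C@H]1C[C@H](N=[N+]=[N-])[C@@H](CO)O1`: > 100000 nM

In an ADME assay on PBMC cells (Homo sapiens) for cytotoxicity, with a stated time of 5 days (a higher number here means a weaker inhibitor, a lower number a stronger inhibitor), compound 2 gives > 100000 nM, which is a limit and not a number. Compound 1 gives > 100000 nM, which is also a limit. Within the data shown here, the series so far therefore comes down to the limit of > 100000 nM in this assay, at which 2 of the 2 values shown sit, and no measured step connects the two compounds.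

Compound 3 `[N-]=[N+]=N[C@H]1C[C@H](n2cnc3c(NCCCCCO)nc(N)nc32)O[C@@H]1CO` is next, with this change from compound 2: 5-hydroxypentyl in place of 1-(hydroxymethyl)-1-methylethyl on a nitrogen on an aromatic ring. In words, 5-hydroxypentyl stands in place of 1-(hydroxymethyl)-1-methylethyl on a nitrogen on an aromatic ring.

Among the measured compounds shown here, with no measured step to draw on, the expectation rests on compound 2 and its limit of > 100000 nM. The expected step is a number no higher from compound 2 to compound 3 (the limit leaves the size open), which means no expected change beyond the scatter in either direction. For compound 3 the estimate in this assay is 100000 nM, with an expected range of 30000 nM to 200000 nM.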

Compound 3, half-maximal inhibitory concentration: > 100000 nM
Compound 3 ended at the assay's limit; the forecaster's own chance of this, stated with the estimate: 80%; the middle value lies on the limit itself.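

In this assay compound 3 gives > 100000 nM as a limit and not a number. No step can be read between compound 2 and compound 3, and the series stays where it was: the limit of > 100000 nM in this assay, at which 3 of the 3 values shown sit.

In this assay the compounds shown leave open whether 5-hydroxypentyl and 1-(hydroxymethyl)-1-methylethyl differ at all.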